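The source may report more compounds than this note shows. Statements on the series, on what has been measured and on what is new or still open speak of the compounds shown alone.

Of the compounds shown here, three carry numbers so far. Compound 1 `COc1ccc(OC)c(/C=N/NC(=O)c2cc(OC)c(OC)c(OC)c2)c1` gives 51.7% in a functional assay on PC-3 cells (Homo sapiens) for antiproliferative activity, read by MTT assay, tested at 5 uM; a lower number here means a weaker effect, a higher number a stronger effect of the compound at the concentration tested. Compound 2 `COc1cc(C2=NN(C(C)=O)C(c3ccc(F)c(F)c3)O2)cc(OC)c1OC` gives 46.9% in this assay, and compound 3 `COc1cc(C2=NN(C(C)=O)C(c3cc(OC)c(OC)c(OC)c3)O2)cc(OC)c1OC` gives 0.1% in this assay. Compound 2 stands second highest of the three; its nearest neighbour is compound 1, whose reading is higher by an amount within the scatter, so the two cannot be ordered, while compound 3 lies far lower, beyond the scatter.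

Compound 4 `COc1ccc(OC)c(C2OC(c3cc(OC)c(OC)c(OC)c3)=NN2C(C)=O)c1` has not yet been measured. It differs from compound 2 in one place: 2,5-dimethoxyphenyl in place of 3,4-difluorophenyl on a saturated ring carbon

Among the compounds with values here, no step between measured compounds is available for this exchange, so the expectation rests on what the three readings show. Compound 3 gives 0.1% in this assay with a heavily methoxylated aryl on that same saturated ring carbon, whereas compound 1, an open-chain analogue bearing 2,5-dimethoxyphenyl, gives 51.7% in this assay. The step from compound 2 to compound 4 is therefore expected to be downward and of moderate size, a number 21.9 percentage points lower from compound 2 to compound 4 (beyond the scatter), with wide uncertainty. Compound 4 is estimated at 25% in this assay, in a range from 2% to 55%.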

Compound 4, a percentage reported as inhibition, at one concentration (the size of the read-out at that concentration, not a potency): 43.2%
The estimate for compound 4 lay 18.2 percentage points below the measured number; measured number inside the range.
By their numbers in this assay, from the lowest: compound 3; then compounds 4, 2 and 1 (each within the scatter of the next).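

On the saturated ring carbon, 2,5-dimethoxyphenyl in place of 3,4-difluorophenyl gives a number 3.7 percentage points lower from compound 2 to compound 4 (within the scatter) in this assay, so this change leaves the reading unresolved from the scatter and the position accepts either aryl group on the evidence of this pair. Methoxy groups on this aryl therefore do not by themselves go with a near-empty reading: compound 3, with its heavily methoxylated aryl on the same carbon, gives 0.1% while compound 4 gives 43.2% in this assay, and the low reading stays confined to compound 3 among the compounds carrying the shared core. No measurement on hand speaks to the reason for these readings.

On these data alone, whether the low reading of compound 3 follows from the number of methoxy groups or from their arrangement stays open, since each aryl pattern is represented by one compound at one concentration. Also open, as far as these compounds go, is how this carbon responds to groups of another kind, such as an aryl bearing an amine or a carboxylic acid, or a plain alkyl chain in place of the aryl.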